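Bromophenyl Replaces the Thiosemicarbazide on the Shared Core

This account rests on a few compounds, and the source may have more. Where it says the series, first, only, none or still open, it means among the compounds named here.

Of the compounds shown here, three built on one shared core have been tested in a functional assay on MCF7 cells (Homo sapiens) for cytotoxicity, read by MTT assay, with a stated time of 72 h; a higher number here means a weaker inhibitor, a lower number a stronger inhibitor. Compound 1 `Cc1cc(Nc2ccc(Cl)cc2)nc(SCc2nc3ccccc3[nH]2)n1` carries a (4-chlorophenyl)amino group and in this assay gives 33600 nM. Compound 2 `Cc1cc(N2CCCCC2)nc(SCc2nc3ccccc3[nH]2)n1` carries piperidin-1-yl instead; in this assay compound 2 gives > 100000 nM, which is a limit of the measurement and not a number. Compound 3 `Cc1cc(NNC(N)=S)nc(SCc2nc3ccccc3[nH]2)n1` carries a small open-chain group on the ring nitrogen; in this assay compound 3 likewise gives > 100000 nM, again a limit rather than a number. Compound 3 thus stands at the limit of > 100000 nM in this assay, at which 2 of the 3 values shown sit, and only compound 1 yields a readable number. The step of an at least 2.9-fold higher number from compound 1 to compound 2 (0.47 log units; beyond the scatter) and the step of an at least 2.9-fold higher number from compound 1 to compound 3 (0.47 log units; beyond the scatter) both run from that number up to a limit, whereas the step that the two limits leave unreadable from compound 2 to compound 3 cannot be sized.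

Compound 4 `Cc1cc(Nc2ccc(Br)cc2)nc(SCc2nc3ccccc3[nH]2)n1` differs from compound 3 by a group of 7 heavy atoms (6 carbon, 1 bromine; one six-membered aromatic ring of carbon only) in place of a group of 4 heavy atoms (1 carbon, 2 nitrogen, 1 sulfur; no ring), on a nitrogen on an aromatic ring. This is close to the reverse of the change that separates compound 1 from compound 3, with bromine in place of chlorine on the entering ring. Because the step of an at least 2.9-fold higher number from compound 1 to compound 3 (0.47 log units; beyond the scatter) was at least modest, the reverse change is expected to lower the number by a comparable amount, landing near compound 1. Compound 4 is therefore expected to give about 30000 nM, within 10000 nM to 90000 nM. That estimate means an expected step of an at least 3.3-fold lower number from compound 3 to compound 4 (0.52 log units; beyond the scatter).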

Compound 4, half-maximal inhibitory concentration: 38000 nM
The estimate for compound 4 lay 1.3-fold (0.10 log units) below the measured number; the range from low to high includes it.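

Bromo in place of chloro on an aromatic carbon gives a 1.1-fold higher number from compound 1 to compound 4 (0.05 log units; within the scatter) in this assay, so compound 1 and compound 4 cannot be told apart, and this change of halogen has no readable effect here. Among the compounds shown here, the earlier compounds showed a readable number for only one group at this position, whereas the 4-bromophenyl group now also stands clearly apart from the two other groups: replacing the open-chain group gives an at least 2.6-fold lower number from compound 3 to compound 4 (0.42 log units; beyond the scatter), and (4-bromophenyl)amino in place of piperidin-1-yl gives an at least 2.6-fold lower number from compound 2 to compound 4 (0.42 log units; beyond the scatter). Those two steps are lower bounds on the real size, as compound 2 and compound 3 carry limits and not numbers: the limit of > 100000 nM in this assay, at which 2 of the 4 values shown sit.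

Open, from the compounds shown here alone, is whether the halogen is needed at all, which a plain phenyl group on the same nitrogen would test, and whether a 4-methoxyphenyl or a 4-fluorophenyl group would read the same as compound 4. Compound 4 gives 38000 nM in this assay. Also open, going by these compounds, is whether any group on this nitrogen, such as a benzyl group or a phenyl ring carrying a carboxylic acid, would give a clearly lower number.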